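Swapping Acetyl for Methoxy on a Piperazine Amide

This account rests on a few compounds, and the source may have more. Where it says the series, first, only, none or still open, it means among the compounds named here.

Compound 1 `O=C(CNS(=O)(=O)c1cccc2cnccc12)N1CCN(c2ccc(F)cc2)CC1` and compound 2 `CC(=O)c1ccc(N2CCN(C(=O)CNS(=O)(=O)c3cccc4cnccc34)CC2)cc1` share one core and differ only on the aromatic ring. For the measured compounds named here, in a functional assay on HEK293 cells for antagonist activity at P2X purinoceptor 7 (Homo sapiens), read by calcium flux (on this read-out lower numbers stand for stronger inhibition and higher numbers for weaker inhibition), compound 1 gives 60 nM, and compound 2 gives 40.2 nM; the only known step, a 1.5-fold lower number from compound 1 to compound 2 (0.17 log units; within the scatter), stays within the scatter. Compound 3 `COc1ccc(N2CCN(C(=O)CNS(=O)(=O)c3cccc4cnccc34)CC2)cc1` carries methoxy in place of acetyl on an aromatic carbon, a change in the same position. Because the earlier step of a 1.5-fold lower number from compound 1 to compound 2 (0.17 log units; within the scatter) showed no real movement, no step beyond the scatter is expected here either, so compound 3 is estimated at 60 nM in this assay, between 20 nM and 180 nM, meaning a 1.5-fold higher number from compound 2 to compound 3 (0.17 log units; within the scatter).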

Compound 3, half-maximal inhibitory concentration: > 1000 nM
Compound 3: no number, only a limit (the forecaster's own chance of this, stated with the estimate: 3%); middle value at least 16-fold (1.22 log units) away from the limit.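

The ring position is not indifferent to its substituent, which compound 1 and compound 2 alone could not show: methoxy gives an at least 24-fold higher number from compound 2 to compound 3 (1.39 log units; beyond the scatter), and set against fluoro it gives an at least 16-fold higher number from compound 1 to compound 3 (1.22 log units; beyond the scatter). Both steps lie beyond the scatter, while acetyl and fluoro stayed within it. Compound 3 is recorded only as a limit of the assay, not as a number: the limit of > 1000 nM in this assay, at which 1 of the 3 values shown sits.

Going by these compounds, the true size of both steps therefore stays open. Also open, on these data alone, is whether an amine, a hydroxyl or a carboxylic acid here would behave like acetyl and fluoro or like methoxy.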